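The compounds below may be only part of what the source reports. "The series", "measured", "known", "first", "only" and "open" are said of these compounds alone.

Compound 1 `C=CC[C@@H]1O[C@H](COCc2ccccc2)[C@@H](OCc2ccccc2)[C@H](OCc2ccccc2)[C@H]1O` is the anchor of this small set. Within the data shown here, in a functional assay on HL-60 cells (Homo sapiens) for antiproliferative activity, read by MTT assay (on this read-out lower numbers stand for stronger inhibition and higher numbers for weaker inhibition), compound 1 gives 15100 nM, and its only neighbour, compound 2 `C=CC[C@@H]1O[C@H](COCc2ccccc2)[C@@H](OCc2ccccc2)[C@H](OCc2ccccc2)[C@H]1OC(C)=O`, gives 26900 nM, so compound 1 stands alongside compound 2 within the scatter rather than apart from it. Among the measured compounds shown here, the single measured step, a 1.8-fold higher number from compound 1 to compound 2 (0.25 log units; within the scatter), touches an oxygen on a saturated carbon and leaves the chain carbon untouched, so it carries no information on the change at hand. Compound 3 `CC(C)C[C@@H]1O[C@H](COCc2ccccc2)[C@@H](OCc2ccccc2)[C@H](OCc2ccccc2)[C@H]1O` differs from compound 1 by isopropyl in place of vinyl on a saturated chain carbon bound to a saturated ring carbon; cut one bond further out, the same change reads allyl to isobutyl. For the measured compounds named here, no measured step bears on this change, so nothing beyond the scatter is expected for compound 3 in this assay. The step of a 1.0-fold lower number from compound 1 to compound 3 (0.00 log units; within the scatter) is expected to be flat. Compound 3 is estimated at 15000 nM, with a range from 6000 nM to 40000 nM.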

Compound 3, half-maximal inhibitory concentration: 8500 nM
The estimate for compound 3 lay 1.8-fold (0.25 log units) above the measured number; the range from low to high includes it.
By their numbers in this assay, from the lowest: compounds 3, 1 and 2 (each within the scatter of the next, the first and the last beyond it).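

In this assay, among these compounds, the step of a 1.8-fold lower number from compound 1 to compound 3 (0.25 log units; within the scatter) gives the first reading at this place, the saturated chain carbon bound to a saturated ring carbon. Isopropyl in place of vinyl, which reads allyl to isobutyl one bond further out, leaves the two compounds within the scatter of each other, so the double bond of the allyl chain can give way to the saturated, branched isobutyl chain without a step beyond the scatter in this series. No supporting data bear on why the two compounds read alike.

On these data alone, whether a longer chain, such as n-hexyl, or a chain ending in an amine or a carboxylic acid would move the number beyond the scatter at this place remains open. Also open, as far as these compounds go, is how acetyl in place of hydrogen on the oxygen reads when the isobutyl chain is present.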